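Removing one fluoro from compound 3

The source may report more compounds than this note shows. Statements on the series, on what has been measured and on what is new or still open speak of the compounds shown alone.

Values in a functional assay on HCC 2998 cells (Homo sapiens) for inhibition; on this read-out lower numbers stand for stronger inhibition of growth and higher numbers for weaker inhibition of growth:
- compound 1 `Nc1ccc(-c2nc3ccc(F)cc3s2)cc1I`: 320 nM
- compound 2 `Nc1ccc(-c2nc3ccc(F)cc3s2)cc1Cl`: 90 nM
- compound 3 `Cc1cc(-c2nc3cc(F)c(F)cc3s2)ccc1N`: > 100000 nM

Compound 3 stands at the limit of > 100000 nM in this assay, at which 1 of the 3 values shown sits; this is a limit and not a number. Compound 4 `Cc1cc(-c2nc3ccc(F)cc3s2)ccc1N` differs from compound 3 in one place: hydrogen in place of fluoro on an aromatic carbon. Among the measured compounds shown here, the only measured step, a 3.6-fold lower number from compound 1 to compound 2 (0.55 log units; beyond the scatter), involves a different change and bears on this one only loosely. Compound 4 does share the core of compound 1 (320 nM) and of compound 2 (90 nM), so a large move to a lower number is expected in this assay. The expected change is an at least 660-fold lower number from compound 3 to compound 4 (2.82 log units; beyond the scatter). For compound 4 the estimate is 150 nM, with an expected range of 20 nM to 3000 nM.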

Compound 4, concentration for 50% growth inhibition: 34700 nM
Compound 4: the middle estimate sits 230-fold (2.36 log units) below what was measured; the whole stated range lies below it.
By their numbers in this assay, from the lowest: compound 2; then compound 1; then compound 4. At a limit, above all of these: compound 3.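

In this assay, with the shared core kept, methyl in place of chloro or iodo moves the number much further than swapping one halogen for the other: a 390-fold higher number from compound 2 to compound 4 (2.59 log units; beyond the scatter) and a 110-fold higher number from compound 1 to compound 4 (2.04 log units; beyond the scatter), against a 3.6-fold lower number from compound 1 to compound 2 (0.55 log units; beyond the scatter). Hydrogen in place of fluoro on the aromatic carbon gives an at least 2.8-fold lower number from compound 3 to compound 4 (0.45 log units; beyond the scatter), so this step has a lower bound only. Compound 3 stands at a limit and not a number: the limit of > 100000 nM in this assay, at which 1 of the 4 values shown sits.

On these data alone, the true size of the fluoro step stays open. So does how a methoxy, a trifluoromethyl or an ethyl group would read in place of the methyl.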